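Turning a Double Bond: Compound 4 Versus Compound 3

The compounds below may be only part of what the source reports. "The series", "measured", "known", "first", "only" and "open" are said of these compounds alone.

Of the compounds shown here, three have been measured in an ADME assay on L6 cells (Rattus norvegicus) for cytotoxicity, read by microscopy and resazurin assay, with a stated time of 72 h; on this read-out higher numbers stand for an effect only at larger amounts of compound and lower numbers for an effect already at smaller amounts. Compound 1 `Cc1cc(/C=C2\S/C(=N\c3ccccc3)N(C3CCCCC3)C2=O)c(C)n1C` gives > 230000 nM, which is a limit of the assay rather than a number. Compound 2 `C/N=C1\S/C(=C\c2ccn(Cc3ccccc3)c2)C(=O)N1C` gives > 290000 nM, again a limit rather than a measured number. Going by the values given here, compound 3 `Cc1cc(/C=C2\SC(=O)NC2=O)c(C)n1-c1ccccc1C(F)(F)F` is the only one with an actual value: in this assay compound 3 gives 64000 nM. Among the compounds with values here, the two limits, the limit of > 230000 nM in this assay, at which 1 of the 3 values shown sits, and (the limit of > 290000 nM in this assay, at which 1 of the 3 values shown sits), mean only that compound 3 sits below both of them; no ordering among the three can be read beyond that.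

Compound 4 `Cc1cc(/C=C2/SC(=O)NC2=O)c(C)n1-c1ccccc1C(F)(F)F` is the unmeasured partner of compound 3. The two are built from the same atoms and bonds and differ only in how one double bond is drawn: the two compounds have the same atoms and bonds and differ only in configuration as drawn: 1 of 1 stereo elements differ; a double bond is drawn Z in compound 3 and E in compound 4. Within the data shown here, no pair of measured compounds in this set differs in such a way, so there is no measured step to lean on. A change of drawn geometry alone gives no ground to expect a shift beyond the usual scatter, so the step from compound 3 to compound 4 is estimated at a 1.1-fold higher number from compound 3 to compound 4 (0.04 log units; within the scatter), essentially none. Compound 4 is therefore expected to give about 70000 nM in this assay, within a range from 25000 nM to 200000 nM.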

Compound 4, half-maximal effective concentration: 43000 nM
The estimate for compound 4 lay 1.6-fold (0.21 log units) above the measured number; measured number inside the range.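

Turning the double bond gives a 1.5-fold lower number from compound 3 to compound 4 (0.17 log units; within the scatter) in this assay. For this pair, then, the drawn geometry of this double bond makes no difference that can be told apart from the ordinary variation between repeated measurements, something the earlier set of one number and two limits could not show. The comparison isolates this single feature, with nothing else in the structures varying: the fact that compounds 3 and 4 differ only in the configuration as drawn

The compounds shown leave open whether the same holds for the double bond in other compounds, such as compound 1 and compound 2, whose results are limits and so offer no number for such a comparison. Also open, from the compounds shown here alone, is what a carboxylic acid or an amine in place of the trifluoromethyl would do to the number in this assay, with either geometry of the double bond.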